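This account rests on a few compounds, and the source may have more. Where it says the series, first, only, none or still open, it means among the compounds named here.

Of the compounds shown here, three share one core and have been tested in an assay on isolated protein for inhibition of ubiquitin carboxyl-terminal hydrolase 7 (Homo sapiens), with stated times of 30 min and 2 h; a lower number here means a stronger inhibitor, a higher number a weaker inhibitor. Compound 1 `Cn1nc2c(=O)n(CC3(O)CCN(Cc4ccc(-c5ccco5)cc4Cl)CC3)cnc2c1-c1ccc(CO)cc1` gives 42.5 nM. Compound 3 `CC(C)NCc1ccc(-c2c3ncn(CC4(O)CCN(Cc5ccc(-c6ccco6)cc5Cl)CC4)c(=O)c3nn2C)cc1` gives 29.1 nM. Compound 2 `Cc1ccc(-c2ccc(CN3CCC(O)(Cn4cnc5c(-c6ccc(CN)cc6)n(C)nc5c4=O)CC3)c(Cl)c2)s1` gives 101 nM, the highest of the three numbers; the nearest is compound 1, the furthest compound 3, and both gaps lie beyond the scatter. Within the data shown here, the only single-point step so far is a 1.5-fold lower number from compound 1 to compound 3 (0.16 log units; within the scatter), a change at the far end of the molecule and not the kind of change now in question.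

Compound 4 `Cn1nc2c(=O)n(CC3(O)CCN(Cc4ccc(-n5cccn5)cc4Cl)CC3)cnc2c1-c1ccc(CN)cc1` differs from compound 2 at one place: 1H-pyrazol-1-yl in place of 5-methylthiophen-2-yl on an aromatic carbon. Among the measured compounds shown here, no measured step exchanges one five-membered aromatic ring for another at this position, and compound 1, which differs from compound 2 in two places at once, cannot separate the two. There is therefore no measured basis for expecting a shift beyond the scatter, though compound 1 hints that a smaller ring here need not cost anything. The expectation is a step of a 1.2-fold lower number from compound 2 to compound 4 (0.07 log units; within the scatter), and compound 4 is estimated at 85 nM, within a range of 30 nM to 250 nM.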

Compound 4, half-maximal inhibitory concentration: 233 nM
Estimate against measurement, compound 4: 2.7-fold (0.44 log units) below; the measured number falls inside the stated range.
By their numbers in this assay, from the lowest: compounds 3 and 1 (each within the scatter of the next); then compound 2; then compound 4.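

In this assay, the step of a 2.3-fold higher number from compound 2 to compound 4 (0.36 log units; beyond the scatter) shows that this place on the chlorinated aromatic ring, para to a large group, responds to the choice of five-membered aromatic ring: 5-methylthiophen-2-yl and 1H-pyrazol-1-yl are not interchangeable, and the pyrazole gives the weaker inhibitor. The exchange changes several things at once, since the sulfur-containing ring gives way to one with two nitrogens, the methyl group is lost, and the hydrogen-bond acceptor count rises, so this single step cannot show which of these matters. Nothing available explains the loss.

The compounds shown leave open whether the step follows the ring atoms or the methyl group. Unsubstituted thiophen-2-yl or 3-methylpyrazol-1-yl at this place, with the rest of compound 2 unchanged, would separate the two.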